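A few compounds are considered here, and "the series" means these few. Any claim that something is new, unique, unknown or untested is made for them only; others in the source may bear on it.

Measured so far: compound 1 `CS(=O)(=O)c1cccc(C#Cc2cc(Cl)ccc2OCC(=O)O)c1` with 15 nM; compound 2 `O=C(O)COc1cc(F)ccc1C#Cc1ccccc1Cl` with 4780 nM; compound 3 `Cc1ccc(S(=O)(=O)N(C)CCCN(C)C)cc1C#Cc1cc(Cl)ccc1OCC(=O)O` with 287 nM.

All three were run in an assay on CHO cells for displacement of a labelled ligand from prostaglandin D2 receptor 2 (Homo sapiens), read by scintillation counting; on this read-out lower numbers stand for stronger inhibition and higher numbers for weaker inhibition. Compound 3 stands second highest of the three numbers: compound 2 gives a higher number than it, and compound 1 a lower one, each gap lying beyond the scatter. Compound 4 `Cc1ccc(S(=O)(=O)N2CCOCC2)cc1C#Cc1cc(Cl)ccc1OCC(=O)O` has not yet been measured. It differs from compound 3 in one place: morpholin-4-yl in place of (3-(dimethylamino)propyl)(methyl)amino on a sulfonyl sulfur. Going by the values given here, no step between two measured compounds covers this kind of change, so the expectation rests on compound 3 alone. A modest step toward a lower number is expected for compound 4, a 1.9-fold lower number from compound 3 to compound 4 (0.28 log units; within the scatter), with no certainty that it exceeds the scatter. Compound 4 is therefore estimated at 150 nM, within 40 nM to 600 nM.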

Compound 4, inhibition constant: 3.6 nM
Beside the measured number, compound 4's estimate is 42-fold (1.62 log units) above it; the measured number lies below the stated range.
By their numbers in this assay, from the lowest: compound 4; then compound 1; then compound 3; then compound 2.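

In this assay the group on the sulfonyl sulfur turns out to matter greatly: morpholin-4-yl in place of (3-(dimethylamino)propyl)(methyl)amino gives an 80-fold lower number from compound 3 to compound 4 (1.90 log units; beyond the scatter) on an otherwise unchanged structure. This single pair shows that the number at this position can move far, and that a six-membered ring is accepted there. Nothing given here accounts for the size of the step. The compounds shown leave open whether the step follows from the ring, from its oxygen or from the loss of the dimethylamino chain. A piperidine or a plain dimethylamine on the sulfonyl sulfur would help separate these.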